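This account rests on a few compounds, and the source may have more. Where it says the series, first, only, none or still open, it means among the compounds named here.

Working notes on the series. All three measured compounds share one core and differ only in the group carried on the second ring. Compound 1 `CCOC(=O)c1cccc(-c2ccc(N(C)C)cc2)c1` gives 40000 nM in an assay on COS-7 cells for inhibition of patatin-like phospholipase domain-containing protein 2 (Mus musculus); on this read-out lower numbers stand for stronger inhibition and higher numbers for weaker inhibition. Compound 2 `CN(C)c1ccc(-c2cccc(N)c2)cc1` gives 100000 nM in this assay, the highest number among the three measured; the step is a 2.5-fold higher number from compound 1 to compound 2 (0.40 log units; beyond the scatter). Compound 3 `CC(C)COC(=O)Nc1cccc(-c2ccc(N(C)C)cc2)c1` gives 22000 nM in this assay, and the step is a 4.5-fold lower number from compound 2 to compound 3 (0.66 log units; beyond the scatter), so compound 2 sits above both neighbours by margins beyond the scatter.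

Compound 4 `CN(C)C(=O)N(C)c1cccc(-c2ccc(N(C)C)cc2)c1` has not yet been measured. Its change from compound 2 is (dimethylcarbamoyl)(methyl)amino in place of amino on an aromatic carbon. Both measured steps bear on it: a 2.5-fold higher number from compound 1 to compound 2 (0.40 log units; beyond the scatter) and a 4.5-fold lower number from compound 2 to compound 3 (0.66 log units; beyond the scatter) are modest, beyond the scatter, and place the bare amino group of compound 2 on the high side. The change to compound 4, like that to compound 3, replaces the free amino group with a larger substituted nitrogen. A modest downward step in this assay is therefore expected, of roughly the size seen because the step of a 4.5-fold lower number from compound 2 to compound 3 (0.66 log units; beyond the scatter) went the same way. Compound 4 is expected to give about 30000 nM in this assay, within 10000 nM to 90000 nM. The expected size of the step is a 3.3-fold lower number from compound 2 to compound 4 (0.52 log units; beyond the scatter).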

Compound 4, half-maximal inhibitory concentration: 70000 nM
Compound 4: the middle estimate sits 2.3-fold (0.37 log units) below what was measured; the measured number falls inside the stated range.
By their numbers in this assay, from the lowest: compounds 3, 1, 4 and 2 (each within the scatter of the next, the first and the last beyond it).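

In this assay, the (dimethylcarbamoyl)(methyl)amino group on this aromatic carbon cannot be told apart from the bare amino group of compound 2 (a 1.4-fold lower number from compound 2 to compound 4 (0.15 log units; within the scatter)) or from the ethoxycarbonyl group of compound 1 (a 1.8-fold higher number from compound 1 to compound 4 (0.24 log units; within the scatter)). A larger substituted nitrogen at this position is therefore not enough on its own to reproduce the step seen with isobutoxycarbonyl on the nitrogen (a 4.5-fold lower number from compound 2 to compound 3 (0.66 log units; beyond the scatter)), and compound 4 goes against any reading of that step as a general effect of substituting the nitrogen. No supporting data are available to account for this outcome.

The compounds shown leave open which part of the entering group, the methyl on the nitrogen or the dimethylcarbamoyl portion, separates compound 4 from the isobutoxycarbonyl substitution of compound 3. They also leave open how a carboxylic acid, an acetylamino group or a longer alkoxycarbonyl chain on the same aromatic carbon would read in this assay on the shared core.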